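A few compounds are considered here, and "the series" means these few. Any claim that something is new, unique, unknown or untested is made for them only; others in the source may bear on it.

In a functional assay on PC-3 cells (Homo sapiens) for inhibition, read by MTT assay, with a stated time of 48 h (a lower number here means a stronger inhibitor, a higher number a weaker inhibitor), compound 1 `Cc1ccc(/C=C2\SC(=O)N(CCNC(=O)Nc3c(C)n(C)n(-c4ccccc4)c3=O)C2=O)cc1` reads 58700 nM and compound 2 `Cc1ccc(/C=C2\SC(=O)N(CC(=O)Nc3c(C)n(C)n(-c4ccccc4)c3=O)C2=O)cc1` reads 45300 nM as a pair within the scatter of each other. Compound 3 `Cc1c(NC(=O)CN2C(=O)S/C(=C\c3ccc(Br)cc3)C2=O)c(=O)n(-c2ccccc2)n1C` reads 17100 nM and so lies below compound 2, beyond the scatter. Compound 4 `Cc1cc(C)c(/C=C2\SC(=O)N(CC(=O)Nc3c(C)n(C)n(-c4ccccc4)c3=O)C2=O)c(C)c1` has not yet been measured. Its change from compound 2 is 2,4,6-trimethylphenyl in place of 4-methylphenyl on a double-bonded chain carbon bound to a double-bonded ring carbon, counted as 2,4,6-trimethylphenyl in place of 4-methylphenyl on a double-bonded chain carbon bound to a double-bonded ring carbon and with the rest of the molecule unchanged.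

Among the measured compounds shown here, one measured step bears on this: a 2.6-fold lower number from compound 2 to compound 3 (0.42 log units; beyond the scatter) is a modest change made on the same aryl group. For the measured compounds named here, no measured compound carries extra methyl groups on that aryl group, so this step gives only a rough scale for changes there and no direction. In this assay the expectation is therefore no shift beyond the scatter, or a modest one of either sign. The estimated step is a 1.1-fold lower number from compound 2 to compound 4 (0.05 log units; within the scatter) and remains an expectation until a reading exists. For compound 4 the estimated value is 40000 nM with an expected range from 16000 nM to 95000 nM as the working figure.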

Compound 4, half-maximal inhibitory concentration: 81600 nM
Compound 4: middle estimate off by 2.0-fold (0.31 log units), on the low side, and the stated range covers the measured number.
By their numbers in this assay, from the lowest: compound 3; then compounds 2, 1 and 4 (each within the scatter of the next).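

In this assay, 2,4,6-trimethylphenyl in place of 4-methylphenyl on the double-bonded chain carbon gives a 1.8-fold higher number from compound 2 to compound 4 (0.26 log units; within the scatter), so at this position the larger aryl group, with 9 heavy atoms against 7, brings no shift that can be told from the scatter. Set against the 4-bromophenyl group, the same 2,4,6-trimethylphenyl group gives a 4.8-fold higher number from compound 3 to compound 4 (0.68 log units; beyond the scatter), which lies beyond the scatter and leaves compound 3 apart from both methyl-bearing aryl compounds with this chain, compound 2 and compound 4, so that among these three aryl groups only 4-bromophenyl gives a lower number. No supporting data bear on why these steps have the size they do. 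

Open, going by these compounds, is whether the lower number of compound 3 extends to other halogens on the aryl group, such as a 4-chlorophenyl or 4-fluorophenyl group, or stays with bromo alone. Also open, on these data alone, is how this position responds to aryl groups carrying an amine, a methoxy group or a carboxylic acid, and whether 2,4,6-trimethylphenyl would read the same on the longer urea chain of compound 1.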